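A few compounds are considered here, and "the series" means these few. Any claim that something is new, unique, unknown or untested is made for them only; others in the source may bear on it.

Of the compounds shown here, two of this set have been measured so far. Compound 1 `COc1cc(C(C)O)c(OC)c2c1C(=O)C=CC2=O` carries a 1-hydroxyethyl group on its aromatic ring, and in a functional assay on L1210 cells (Mus musculus) for cytotoxicity (a lower number here means that less compound is needed, a higher number that more compound is needed for the effect), compound 1 gives 0.132 ug/mL. Compound 2 `CCC(O)C1=CC(=O)c2c(OC)ccc(OC)c2C1=O` instead carries a 1-hydroxypropyl group on the quinone part of the shared core, and in this assay compound 2 gives 0.516 ug/mL. Of these two numbers, compound 2 has the higher one, and the gap to compound 1 is wider than the ordinary scatter of repeated runs, so compound 2 needs more material for the same effect.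

Compound 3 `COc1ccc(OC)c2c1C(=O)C=C(CO)C2=O` is the next step. It differs from compound 2 in one place: hydrogen in place of ethyl on a saturated chain carbon bound to a double-bonded ring carbon and an oxygen on a saturated carbon. The side chain shrinks from 1-hydroxypropyl to hydroxymethyl while everything else on the core stays as it is.

Among the compounds with values here, no measured pair in this set shows what such a shortening of the chain does. The expectation is therefore a step from compound 2 to compound 3 of a 1.1-fold lower number from compound 2 to compound 3 (0.06 log units; within the scatter) in this assay, small enough to sit within the scatter, with no confident direction. On that basis compound 3 is estimated to give 0.45 ug/mL in this assay, likely between 0.15 ug/mL and 1.3 ug/mL.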

Compound 3, concentration for half-maximal effect: 0.524 ug/mL
Compound 3: middle estimate off by 1.2-fold (0.07 log units), on the low side; the measured number falls inside the stated range.
By their numbers in this assay, from the lowest: compound 1; then compounds 2 and 3 (each within the scatter of the next).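

Within the data shown here, this is the first measured step at this place, a saturated chain carbon bound to a double-bonded ring carbon and an oxygen on a saturated carbon. In this assay, shortening 1-hydroxypropyl to hydroxymethyl gives a 1.0-fold higher number from compound 2 to compound 3 (0.01 log units; within the scatter) and leaves compound 2 and compound 3 indistinguishable, so for this pair the ethyl group can be replaced by hydrogen with no change that stands out from the ordinary spread of repeat runs. Nothing in the data explains why the two numbers agree.

Among these compounds, one pair covers only one change at one place, so it remains open whether the numbers would also stay together with a longer chain such as 1-hydroxybutyl, or with an amine or a carboxylic acid on this carbon in place of the hydroxyl group. Compound 1 differs from both of these compounds in more than one place, so what the same kind of shortening would do to its 1-hydroxyethyl group also stays open.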